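This account rests on a few compounds, and the source may have more. Where it says the series, first, only, none or still open, it means among the compounds named here.

Measured compounds:
Compound 1 `NC(=O)CN(CCC(c1ccccc1)c1ccccc1)C(=O)CN(CCC(c1ccccc1)c1ccccc1)C(=O)CNCC1CCCO1`: 2720 nM
Compound 2 `O=C1CN(CC2CCCO2)C(=O)CN1CCC(c1ccccc1)c1ccccc1`: "not determined" (no result reported)

Among the measured compounds shown here, in an ADME assay on MDA-MB-231 cells (Homo sapiens) for cytotoxicity, with a stated time of 72 h (on this read-out higher numbers stand for weaker inhibition of growth and lower numbers for stronger inhibition of growth), compound 1 gives 2720 nM, the only number in the set, while compound 2 has no result. Compound 3 `NC(=O)CN(CCC(c1ccccc1)c1ccccc1)C(=O)CNCCC(c1ccccc1)c1ccccc1` differs from compound 1 by hydrogen in place of ((((oxolan-2-yl)methyl)amino)methyl)carbonyl on an amine nitrogen. For the measured compounds named here, with no step between measured compounds to lean on, the expected step is a moderate loss of growth inhibition beyond the usual scatter, since a sizeable part of compound 1 is removed. Compound 3 is therefore estimated at 6500 nM, within 1800 nM to 25000 nM, a step of a 2.4-fold higher number from compound 1 to compound 3 (0.38 log units; beyond the scatter).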

Compound 3, concentration for 50% growth inhibition: 3080 nM
The estimate for compound 3 lay 2.1-fold (0.32 log units) above the measured number; low and high end bracket the measured number.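

In this assay, the exchange of ((((oxolan-2-yl)methyl)amino)methyl)carbonyl for hydrogen on an amine nitrogen gives a 1.1-fold higher number from compound 1 to compound 3 (0.05 log units; within the scatter), so this sizeable group can go without a change in the read-out beyond the scatter. For this pair, growth inhibition at this position does not rest on the group that leaves. The data offer no explanation for this result. Going by these compounds, whether an acetyl group, a longer alkyl chain or a carboxylic acid on that nitrogen would leave the read-out equally unchanged remains open.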